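Swapping the aryl ether in a triazole series: expected tolerance

The source may report more compounds than this note shows. Statements on the series, on what has been measured and on what is new or still open speak of the compounds shown alone.

Of the compounds shown here, three have been tested in a toxicity assay on MT4 cells (Homo sapiens) for cytotoxicity, read by MTT assay, with a stated time of 5 days; a lower number here means that less compound is tolerated, a higher number that more compound is tolerated. Compound 1, `CC(=O)Nc1ccc(OCC(=O)NNC(=S)NCc2ccccc2)cc1`, gives 83.5 ug/mL. Compound 2, `Cc1ccc(C(C)C)c(OCc2nnc(SCC(=O)Nc3ccc([N+](=O)[O-])cc3)n2Cc2ccccc2)c1`, gives 11.2 ug/mL, and compound 3, `CCOC(=O)c1ccc(NC(=O)CSc2nnc(COc3cc(C)ccc3C(C)C)n2Cc2ccccc2)cc1`, gives 19.8 ug/mL. For the measured compounds named here, the only step between close relatives is a 1.8-fold higher number from compound 2 to compound 3 (0.25 log units; within the scatter), a change at the far end of the molecule from the aryl ether. Against the three numbers, compound 3 stands second highest, close to compound 2 and well apart from compound 1, which shares no single-point relation with it.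

Compound 4, `CCOC(=O)c1ccc(NC(=O)CSc2nnc(COc3ccc(NC(C)=O)cc3)n2Cc2ccccc2)cc1`, arises from compound 3 by 4-acetamidophenyl in place of 2-isopropyl-5-methylphenyl on an oxygen on a saturated carbon. Going by the values given here, no measured step covers this change; the one step known concerns a different part of the molecule and was within the scatter. The group that enters is also present in compound 1, whose value is the highest of the three, but the cores differ, so only a loose guide exists. The step in this assay is therefore expected to be modest and upward, a 2.0-fold higher number from compound 3 to compound 4 (0.31 log units; beyond the scatter). Compound 4 is estimated at 40 ug/mL, within a range from 15 ug/mL to 100 ug/mL.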

Compound 4, half-maximal cytotoxic concentration: 91.1 ug/mL
Compound 4: middle estimate off by 2.3-fold (0.36 log units), on the low side, within the range that was stated.
By their numbers in this assay, from the lowest: compounds 2 and 3 (each within the scatter of the next); then compounds 1 and 4 (each within the scatter of the next).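

In this assay, for the compounds shown here, the group on the ether oxygen clearly matters: 4-acetamidophenyl in place of 2-isopropyl-5-methylphenyl gives a 4.6-fold higher number from compound 3 to compound 4 (0.66 log units; beyond the scatter) here, whereas the only earlier step, at the far end of the molecule, stayed within the scatter. The two groups have the same number of heavy atoms and each holds one six-membered aromatic ring, but only the entering group carries a hydrogen-bond donor, a hydrogen-bond acceptor and a double bond outside the ring. No measurement shown accounts for the step.

From the compounds shown here alone, it remains open whether the step goes with gaining the acetamido group or with losing the isopropyl and methyl groups, as the swap does both at once. A plain phenyl group, or an amine on that ring, would be needed to tell these apart, and whether the step also holds with the nitro group of compound 2 is equally unknown.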